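Azide for Anilino on the Ribosylated Core

A few compounds are considered here, and "the series" means these few. Any claim that something is new, unique, unknown or untested is made for them only; others in the source may bear on it.

Among the compounds with values here, in a functional assay (Homo sapiens) for inhibition of Nucleic Acid, tested at 100 uM (on this read-out lower numbers stand for less inhibition and higher numbers for more inhibition at the one concentration tested (going by the name of the read-out)), compound 1 `CSc1[nH]ccc2ncnc1-2` gives 4% and compound 3 `CNc1[nH]ccc2ncnc1-2` gives 18%; the only single-point step measured, a number 14 percentage points higher from compound 1 to compound 3 (beyond the scatter), is modest. Compound 2 `OC[C@H]1OC(n2cnc3c(Nc4ccccc4)nccc32)[C@H](O)[C@@H]1O` gives 4%, level with compound 1 and together with it the lowest of the three numbers. Compound 4 `[N-]=[N+]=Nc1nccc2c1ncn2C1O[C@H](CO)[C@@H](O)[C@H]1O` differs from compound 2 by azido in place of anilino on an aromatic carbon. Within the data shown here, no measured step exchanges these groups; the step from compound 1 to compound 3 swaps a different pair at an aromatic carbon of the same core, so it bears only loosely. A small rise or no change beyond the scatter is expected, with a number 5 percentage points higher from compound 2 to compound 4 (within the scatter) as the estimated step. Compound 4 is therefore estimated at 9%, between -6% and 26%.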

Compound 4, a percentage reported as inhibition, at one concentration (the size of the read-out at that concentration, not a potency): 4%
Compound 4: the middle estimate sits 5 percentage points above what was measured, within the range that was stated.
By their numbers in this assay, from the lowest: compounds 1, 2 and 4 (each within the scatter of the next); then compound 3.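

In this assay, azido in place of anilino on an aromatic carbon next to the ring nitrogen gives no change at the digits printed from compound 2 to compound 4 (within the scatter). Within the data shown here, this is the first reading of a change at this position on this core, and here removing the six-membered aromatic ring of carbon and the hydrogen-bond donor of anilino goes with no shift beyond the scatter. Nothing measured here accounts for this result. As far as these compounds go, whether a primary amine or a methoxy group at this position would move the number beyond the scatter remains open.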